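A Methoxyphenyl Amine Replaces the Ethynylphenyl of Compound 2

A few compounds are considered here, and "the series" means these few. Any claim that something is new, unique, unknown or untested is made for them only; others in the source may bear on it.

Three measured compounds share one core and differ only in the aryl group on the amine nitrogen. Compound 1 `COc1cc2ncnc(Nc3ccc(F)c(Cl)c3)c2cc1OCCCCC(=O)Nc1ccc(S(N)(=O)=O)cc1` carries a 3-chloro-4-fluorophenyl there, and in a functional assay on NCI-H1975 cells (Homo sapiens) for antiproliferative activity, read by MTT assay, with a stated time of 72 h (a lower number here means a stronger inhibitor, a higher number a weaker inhibitor), compound 1 gives 35600 nM. Compound 2 `C#Cc1cccc(Nc2ncnc3cc(OC)c(OCCCCC(=O)Nc4ccc(S(N)(=O)=O)cc4)cc23)c1` carries a 3-ethynylphenyl, and in this assay compound 2 gives 18800 nM. Compound 3 `COc1cc2ncnc(Nc3cccc(F)c3)c2cc1OCCCCC(=O)Nc1ccc(S(N)(=O)=O)cc1` carries a 3-fluorophenyl. For compound 3 this assay reports only a limit, > 40000 nM, which is the limit of > 40000 nM in this assay, at which 1 of the 3 values shown sits. Compound 2 stands nearest to compound 1, the step between them being a 1.9-fold lower number from compound 1 to compound 2 (0.28 log units; within the scatter), so the two cannot be told apart. an at least 1.1-fold higher number from compound 1 to compound 3 (0.05 log units; that floor lies within the scatter) also stays within the scatter, whereas an at least 2.1-fold higher number from compound 2 to compound 3 (0.32 log units; beyond the scatter) is at least modest.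

Compound 4 `COc1ccc(Nc2ncnc3cc(OC)c(OCCCCC(=O)Nc4ccc(S(N)(=O)=O)cc4)cc23)cc1` is not yet measured. It differs from compound 2 by 4-methoxyphenyl in place of 3-ethynylphenyl on a nitrogen on an aromatic ring. All three measured steps concern this same ring on the amine nitrogen, and the largest of them, an at least 2.1-fold higher number from compound 2 to compound 3 (0.32 log units; beyond the scatter), shows that removing the ethynyl from compound 2 has already moved the number toward the limit. Compound 4 is therefore expected to give a higher number in this assay, estimated at 38000 nM, within 13000 nM to 90000 nM. The expected step is a 2.0-fold higher number from compound 2 to compound 4 (0.31 log units; beyond the scatter), with a fair chance that only a limit is reported.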

Compound 4, half-maximal inhibitory concentration: 30200 nM
Compound 4: middle estimate off by 1.3-fold (0.10 log units), on the high side; the measured number falls inside the stated range.
By their numbers in this assay, from the lowest: compounds 2, 4 and 1 (each within the scatter of the next). At a limit, above all of these: compound 3.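

In this assay, compound 4 is the only compound shown with an oxygen in the aryl group on this nitrogen, yet a 1.6-fold higher number from compound 2 to compound 4 (0.21 log units; within the scatter) and a 1.2-fold lower number from compound 1 to compound 4 (0.07 log units; within the scatter), so the 4-methoxyphenyl cannot be told apart from either the 3-ethynylphenyl or the 3-chloro-4-fluorophenyl. This qualifies the earlier at least 2.1-fold higher number from compound 2 to compound 3 (0.32 log units; beyond the scatter): compound 4 also lacks the ethynyl and its step from compound 2 stays within the scatter, so losing the ethynyl does not by itself separate a compound from compound 2. The step of an at least 1.3-fold lower number from compound 3 to compound 4 (0.12 log units; that floor lies within the scatter) offers only a floor, so compound 3, whose entry is a limit and not a number, cannot be placed against compound 4: the limit of > 40000 nM in this assay, at which 1 of the 4 values shown sits.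

The compounds shown leave open whether any aryl group on this nitrogen, such as one carrying a morpholine or a carboxylic acid, would move the number beyond the scatter from compound 2. Going by these compounds, what a longer chain, or a carboxylic acid in place of the sulfonamide, would do in this assay also stays open.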